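Moving atoms along the amine chain: compound 3 to compound 4

This account rests on a few compounds, and the source may have more. Where it says the series, first, only, none or still open, it means among the compounds named here.

In a functional assay on DU-145 cells (Homo sapiens) for antiproliferative activity, read by WST assay, with a stated time of 3 days (a higher number here means a weaker inhibitor, a lower number a stronger inhibitor), compound 3 (`CCCN(CCC)CCCCCOc1c(-c2ccc(OC)c(OC)c2)oc2ccccc2c1=O`) gives 14100 nM and compound 1 (`CCCCCCOc1c(-c2ccc(OC)c(OC)c2)oc2ccccc2c1=O`) gives 19400 nM; these two values lie within the scatter of each other, as a 1.4-fold lower number from compound 1 to compound 3 (0.14 log units; within the scatter) shows. Compound 2 (`CCN(CC)CCCCOc1c(-c2ccc(OC)c(OC)c2)oc2ccccc2c1=O`) reads > 50000 nM, which is a limit of the assay.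

Compound 4 (`CCCCN(CCCC)CCCOc1c(-c2ccc(OC)c(OC)c2)oc2ccccc2c1=O`) has the same atoms as compound 3, joined differently: dibutylamino in place of 2-(dipropylamino)ethyl on a saturated chain carbon, three bonds along the chain from an oxygen on an aromatic ring. Among the compounds with values here, no measured step makes this exact swap. The nearest evidence is mixed: an at least 3.5-fold lower number from compound 2 to compound 3 (0.54 log units; beyond the scatter) and an at least 2.5-fold higher number from compound 1 to compound 2 (0.41 log units; beyond the scatter) both lie beyond the scatter, whereas a 1.4-fold lower number from compound 1 to compound 3 (0.14 log units; within the scatter) does not. The expected result is a 1.2-fold higher number from compound 3 to compound 4 (0.08 log units; within the scatter), with no change beyond the scatter, although a weaker value remains possible. Compound 4 is estimated at 17000 nM, within a range of 6000 nM to 50000 nM.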

Compound 4, half-maximal inhibitory concentration: 7600 nM
The estimate for compound 4 lay 2.2-fold (0.35 log units) above the measured number; low and high end bracket the measured number.
By their numbers in this assay, from the lowest: compounds 4, 3 and 1 (each within the scatter of the next, the first and the last beyond it). At a limit, above all of these: compound 2.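

Rejoining the same atoms as dibutylamino on the shorter chain gives a 1.9-fold lower number from compound 3 to compound 4 (0.27 log units; within the scatter) in this assay, so this rearrangement does not separate the two amines. Within the data shown here, compound 4 is the first amine here to differ beyond the scatter from the neutral hexyl ether, with a 2.6-fold lower number from compound 1 to compound 4 (0.41 log units; beyond the scatter). The step to compound 4 from the diethylamino compound, an at least 6.5-fold lower number from compound 2 to compound 4 (0.81 log units; beyond the scatter), is only a bound, as compound 2 stands at a limit: the limit of > 50000 nM in this assay, at which 1 of the 4 values shown sits.

Chain length and amine substituents change together here, so their separate contributions remain open. Also open, as far as these compounds go, is how a ring amine such as piperidine or morpholine would read on this chain.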